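Swapping methyl for fluoro on the triazole-bound phenyl ring

The source may hold more compounds than are shown below. What is called first, only, known or untested is meant among the compounds shown, and "the series" means these compounds.

The measured compounds:
- compound 1, `O=c1[nH]cc(S(=O)(=O)Nc2ccccc2-c2cn(-c3ccccc3F)nn2)c(=O)[nH]1`: > 100000 nM
- compound 2, `O=c1[nH]cc(S(=O)(=O)Nc2cccc(-c3cn(-c4ccc(Cl)cc4)nn3)c2)c(=O)[nH]1`: 11300 nM
- compound 3, `Cc1cccc(-n2cc(-c3ccc(NS(=O)(=O)c4c[nH]c(=O)[nH]c4=O)cc3)nn2)c1`: 28300 nM

All three share one core, a sulfonamide carrying a triazole with an aryl group on its far side. In an ADME assay on GES1 cells (Homo sapiens) for cytotoxicity, read by MTT assay, with a stated time of 24 h (a lower number here means that less compound is tolerated, a higher number that more compound is tolerated), compound 1 reaches only the limit of the measurement, > 100000 nM, and gives no number. The value for compound 1 is the limit named in the limit of > 100000 nM in this assay, at which 1 of the 3 values shown sits. Of the two real numbers, compound 3 stands highest in this assay with 28300 nM, and compound 2 sits lower at 11300 nM, a gap beyond the usual scatter.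

Compound 4, `O=c1[nH]cc(S(=O)(=O)Nc2ccc(-c3cn(-c4cccc(F)c4)nn3)cc2)c(=O)[nH]1`, differs from compound 3 in one place: fluoro in place of methyl on an aromatic carbon, that is, 3-methylphenyl becomes 3-fluorophenyl, on an aromatic carbon of a six-membered aromatic ring of carbon only. Going by the values given here, no step of this kind has been measured here, so the expectation leans on compound 3 alone. The step from compound 3 to compound 4 in this assay is expected to be small, a 1.1-fold higher number from compound 3 to compound 4 (0.03 log units; within the scatter), and not beyond the scatter in either direction. For compound 4 the estimated value in this assay is 30000 nM, with a range from 12000 nM to 75000 nM.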

Compound 4, half-maximal cytotoxic concentration: "not toxic" (no number reported)
The entry for compound 4 holds no number; the estimate stays without a comparison.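

In this assay, going by these compounds alone, compound 4 is reported only as "not toxic", without a number, so no step from compound 3 to compound 4 can be read. The compounds shown leave open how far fluoro in place of methyl changes the tolerated concentration, and the one other entry without a real number is a limit: the limit of > 100000 nM in this assay, at which 1 of the 4 values shown sits.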